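From chloro to cyano on compound 2

The source may hold more compounds than are shown below. What is called first, only, known or untested is meant among the compounds shown, and "the series" means these compounds.

Compound 1 `CC(O)(c1ccc(N2CCN(S(=O)(=O)c3ccc(N)nc3)CC2)cc1)C(F)(F)F` | < 14 mL.min-1.g-1 (a limit)
Compound 2 `Nc1ccc(S(=O)(=O)c2ccc(-c3ncc(C(O)(C(F)(F)F)C(F)(F)F)cc3Cl)cc2)cn1` | 18 mL.min-1.g-1

Going by the values given here, in an ADME assay (liver) for metabolic stability, with Liver microsome (Rattus norvegicus) as the target, using microsomes and NADPH, with a stated time of 30 min, at 37 degrees C, tested at 1 uM (a higher number here means faster removal of the compound, a lower number slower removal), compound 2 gives the only actual number so far (18 mL.min-1.g-1). Compound 1 is reported only as a limit (< 14 mL.min-1.g-1).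

Compound 3 `N#Cc1cc(C(O)(C(F)(F)F)C(F)(F)F)cnc1-c1ccc(S(=O)(=O)c2ccc(N)nc2)cc1` has not yet been measured. It carries cyano in place of chloro on an aromatic carbon at a place ortho to a large group and meta to a 2,2,2-trifluoro-1-hydroxy-1-(trifluoromethyl)ethyl group. Among the compounds with values here, no measured step shows what this exchange does, so compound 2 (18 mL.min-1.g-1) remains the sole anchor. The expected step (a 1.3-fold lower number from compound 2 to compound 3 (0.11 log units; within the scatter)) is estimated to stay within the usual scatter, with no clear direction. In this assay the expected value for compound 3 is 14 mL.min-1.g-1 with an estimated range from 8 mL.min-1.g-1 to 28 mL.min-1.g-1 and a real chance that the outcome is only a limit.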

Compound 3, intrinsic clearance in microsomes: 27 mL.min-1.g-1
For compound 3 the middle estimate is 1.9-fold (0.29 log units) below the measured one; low and high end bracket the measured number.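

In this assay, going by these compounds alone, the exchange of chloro for cyano, on an aromatic carbon ortho to a large group and two atoms from the ring nitrogen, gives the first step that can be read at this place: a 1.5-fold higher number from compound 2 to compound 3 (0.18 log units; within the scatter). The single chlorine atom can therefore give way to the two heavy atoms of cyano, with its added hydrogen-bond acceptor, without a difference that stands clear of repeat measurements. Compound 1 differs from the others in more than one place and rests only on a limit of the assay: the limit of < 14 mL.min-1.g-1 in this assay, at which 1 of the 3 values shown sits.

From the compounds shown here alone, one exchange cannot show how wide this freedom is, and how a methyl group, a fluorine atom or an amine at this carbon would read in this assay stays open. Also open, going by these compounds, is whether cyano in place of chloro would read the same on another core.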